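A Methoxy Added to the Weakest of Three

A few compounds are considered here, and "the series" means these few. Any claim that something is new, unique, unknown or untested is made for them only; others in the source may bear on it.

Three compounds share a common core and differ only in the aromatic portion carried on the far end of it. Compound 1 `O=C(COc1cccc(Cl)c1)NC1CCN(Cc2ccc(-c3ccccn3)cc2)CC1` is one of them; in an assay on HEK293 cells for displacement of a labelled ligand from melanin-concentrating hormone receptor 1 (Homo sapiens) (a higher number here means a weaker inhibitor, a lower number a stronger inhibitor), compound 1 gives 120 nM. Compound 2 `O=C(COc1cccc(Cl)c1)NC1CCN(Cc2cccc(-n3cccc3)c2)CC1` is the second, and in this assay compound 2 gives 297 nM. Compound 3 `O=C(COc1cccc(Cl)c1)NC1CCN(Cc2ccn(-c3ccccc3)c2)CC1` is the third, and in this assay compound 3 gives 710 nM, the highest of the three numbers: its nearest neighbour is compound 2, compound 1 lies further off, and both gaps stand beyond the scatter.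

Compound 4 `COc1ccc(-n2ccc(CN3CCC(NC(=O)COc4cccc(Cl)c4)CC3)c2)cc1` differs from compound 3 in one place, methoxy in place of hydrogen on an aromatic carbon, para to a large group, so that the phenyl becomes a 4-methoxyphenyl. Among the measured compounds shown here, no pair of measured compounds shows what such an addition does on this core, so the size of the step cannot be read from earlier numbers. One expects a modest change at most, the step from compound 3 to compound 4 in this assay estimated at a 1.4-fold lower number from compound 3 to compound 4 (0.15 log units; within the scatter), with no firm direction and possibly nothing beyond the scatter. Compound 4 is therefore expected to give about 500 nM in this assay, within an estimated range from 180 nM to 1500 nM.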

Compound 4, half-maximal inhibitory concentration: 100 nM
Compound 4: the middle estimate sits 5.0-fold (0.70 log units) above what was measured, outside the stated range (below it).
By their numbers in this assay, from the lowest: compounds 4 and 1 (each within the scatter of the next); then compound 2; then compound 3.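

In this assay the single addition of methoxy gives a 7.1-fold lower number from compound 3 to compound 4 (0.85 log units; beyond the scatter) and so lies beyond the scatter, which shows that this carbon of the phenyl ring is a place where the read-out responds to substitution. Compounds 1, 2 and 3 could not show this, as no two of them differ in one place, and their values could be set side by side only as separate aromatic portions on the shared core. Among the compounds shown here, the change from phenyl to 4-methoxyphenyl is now the one measured step on this core, and it turns the compound with the highest number of the first three into one with a far lower number. Nothing measured here accounts for the size of this step.

The compounds shown leave open whether the step needs the whole methoxy group, since a hydroxyl, a methyl, an ethoxy or a fluorine on the same carbon would separate the oxygen from the carbon it carries. They also leave open whether methoxy on another carbon of this phenyl ring, or on the aromatic portions of compound 1 and compound 2, would give a step of similar size.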